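This account rests on a few compounds, and the source may have more. Where it says the series, first, only, none or still open, it means among the compounds named here.

In a functional assay on MIA PaCa-2 cells (Homo sapiens) for antiproliferative activity, read by WST assay, with a stated time of 72 h (on this read-out lower numbers stand for stronger inhibition and higher numbers for weaker inhibition), compound 1 `COc1ccc2[nH]c(-c3nc(C)no3)cc2c1` gives > 50000 nM, which is a limit of the assay and not a number. Compound 2 `COc1ccc2[nH]c(-c3nc(-c4ccccc4)no3)cc2c1` gives 32600 nM. Compound 3 `Clc1ccc(-c2noc(-c3cc4ccccc4[nH]3)n2)cc1` gives 19200 nM.

Compound 3 thus carries the lowest of the two real numbers, but its gap to compound 2 lies within the scatter, so the two cannot be ranked. Compound 4 `COc1ccc2[nH]c(-c3nc(-c4ccc(Cl)cc4)no3)cc2c1` has not yet been measured; it differs from compound 3 by methoxy in place of hydrogen on an aromatic carbon. Among the compounds with values here, the only measured step, an at least 1.5-fold lower number from compound 1 to compound 2 (0.18 log units; that floor lies within the scatter), concerns a different change, so no measured step bears on this one. With nothing pointing either way, the expected step in this assay is none beyond the scatter. For compound 4 the estimate is 20000 nM, with a range from 8000 nM to 50000 nM, which means an expected step of a 1.0-fold higher number from compound 3 to compound 4 (0.02 log units; within the scatter).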

Compound 4, half-maximal inhibitory concentration: 22700 nM
The estimate for compound 4 lay 1.1-fold (0.05 log units) below the measured number, and the stated range covers the measured number.
By their numbers in this assay, from the lowest: compounds 3, 4 and 2 (each within the scatter of the next). At a limit, above all of these: compound 1.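

In this assay, methoxy in place of hydrogen on an aromatic carbon of the fused system gives a 1.2-fold higher number from compound 3 to compound 4 (0.07 log units; within the scatter), and chloro in place of hydrogen on an aromatic carbon gives a 1.4-fold lower number from compound 2 to compound 4 (0.16 log units; within the scatter), so neither change moves the number beyond the scatter. Swapping methyl for 4-chlorophenyl gives an at least 2.2-fold lower number from compound 1 to compound 4 (0.34 log units; beyond the scatter), the only new step beyond the scatter. Compound 1 stands at a limit of the assay, not a number, so this step is only a floor: the limit of > 50000 nM in this assay, at which 1 of the 4 values shown sits.

On these data alone, what an amine or a carboxylic acid would do in place of the methoxy remains open.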